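A Third Methoxy on the Carbonyl-Side Aryl Group

A few compounds are considered here, and "the series" means these few. Any claim that something is new, unique, unknown or untested is made for them only; others in the source may bear on it.

Compound 2 `COc1ccc(C(=O)/C=C/c2cc(-c3cc(OC)c(OC)c(OC)c3)n[nH]2)cc1OC` was examined in a functional assay on NCI-H226 cells (Homo sapiens) for cytotoxicity, read by sulforhodamine B assay, with a stated time of 48 h, tested at 0.01 uM (a higher number here means a weaker effect of the compound at the concentration tested, a lower number a stronger effect), where compound 2 gives 98%. Among the three measured compounds it stands second highest: compound 3 `COc1cc(-c2cc(/C=C/C(=O)c3ccc(F)c(F)c3)[nH]n2)cc(OC)c1OC` gives 99%, and compound 1 `COc1cc(-c2cc(/C=C/C(=O)c3ccc(N)cc3)[nH]n2)cc(OC)c1OC` gives 92%. The step of a number 1 percentage points higher from compound 2 to compound 3 (within the scatter) and the step of a number 6 percentage points higher from compound 1 to compound 2 (within the scatter) both fall within the scatter, as does a number 7 percentage points higher from compound 1 to compound 3 (within the scatter). Compound 4 `COc1cc(C(=O)/C=C/c2cc(-c3cc(OC)c(OC)c(OC)c3)n[nH]2)cc(OC)c1OC` differs from compound 2 in one place: methoxy in place of hydrogen on an aromatic carbon. The measured steps that bear on this change all alter the aryl group on the carbonyl carbon, and none of them moved the read-out beyond the scatter, so no step beyond the scatter is expected in this assay. Compound 4 is therefore estimated at 97%, between 88% and 105%, an expected step of a number 1 percentage points lower from compound 2 to compound 4 (within the scatter).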

Compound 4, a percentage reported as activity, at one concentration (the size of the read-out at that concentration, not a potency): 99%
Compound 4: middle estimate off by 2 percentage points, on the low side; the range from low to high includes it.
By their numbers in this assay, from the lowest: compounds 1, 2, 3 and 4 (each within the scatter of the next).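

The new step in this assay is a number 1 percentage points higher from compound 2 to compound 4 (within the scatter). Unlike the earlier steps, which exchanged one aryl group on the carbonyl carbon for another, this one adds a single methoxy to an aromatic carbon ortho to a methoxy group, and it leaves the read-out within the scatter. No measured evidence bears on this result. On these data alone, whether a hydroxy group, an amine or a longer chain such as ethoxy on this carbon would shift the read-out beyond the scatter remains open, as does whether compound 2 and compound 4 would separate at a higher concentration.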